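A few compounds are considered here, and "the series" means these few. Any claim that something is new, unique, unknown or untested is made for them only; others in the source may bear on it.

Of the compounds shown here, two built on one shared core have been tested in a functional assay on RPMI-8226 cells (Homo sapiens) for inhibition, read by sulforhodamine B assay, with a stated time of 48 h; a higher number here means that more compound is tolerated, a lower number that less compound is tolerated. Compound 1, `COc1cc(-c2nn(-c3cccc(NC(=O)c4ccc(Cl)c(C(F)(F)F)c4)c3)cc2-c2ccncc2)ccc1Cl`, returns only a limit of the assay in this assay: > 32500 nM. Compound 2, `COc1cc(-c2nn(-c3cccc(NC(=O)Nc4ccc(Cl)c(C(F)(F)F)c4)c3)cc2-c2ccncc2)ccc1Cl`, likewise returns only a limit in this assay: > 32500 nM. The step that the two limits leave unreadable from compound 1 to compound 2 therefore cannot be read as a number, and the limit of > 32500 nM in this assay, at which 2 of the 2 values shown sit, sums up all that is known about where compound 2 stands: both measured values sit at the same limit. Compound 3, `COc1cc(-c2nn(-c3cccc(NC(=O)c4ccccc4)c3)cc2-c2ccncc2)ccc1Cl`, has not been measured. It differs from compound 2 by phenyl in place of (4-chloro-3-(trifluoromethyl)phenyl)amino on a carbonyl carbon. Within the data shown here, no measured step touches this kind of change, and the single measured step, from compound 1 to compound 2, gives no readable size or direction to lean on. With both known compounds at the limit, compound 3 is expected to remain at or near that limit as well, so the step that the limit leaves unreadable from compound 2 to compound 3 is expected to be small or itself unreadable. The estimate for compound 3 in this assay is 40000 nM, between 15000 nM and 150000 nM, with a strong chance that again only a limit is reported.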

Compound 3, concentration lethal to 50% of the cells: > 100000 nM
Compound 3 ended at the assay's limit; the forecaster's own chance of this, stated with the estimate: 70%; at least 2.5-fold (0.39 log units) between middle value and limit.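

In this assay, among these compounds, compound 3 returns only a limit, as do compound 1 and compound 2, so no step between any of them can be read. The compounds shown leave open whether changing the group on the carbonyl carbon alters the concentration lethal to these cells at all, and at what concentration any of the three would reach it.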